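Fluoro Added to the Phenyl of Compound 1

The source may report more compounds than this note shows. Statements on the series, on what has been measured and on what is new or still open speak of the compounds shown alone.

Compound 1 `COc1cc(OC)cc(-n2c(-c3ccccc3)nc(C)c2C)c1` stands second highest of the three compounds measured in a functional assay, with a stated time of 15 min, tested at 40 uM (on this read-out lower numbers stand for a weaker effect and higher numbers for a stronger effect at the one concentration tested), where compound 1 gives 49.5%. Compound 3 `COc1ccc(-n2c(-c3ccccc3)nc(C)c2C)cc1` gives 63.2%, and compound 2 `COc1ccc(-n2c(-c3ccc(F)cc3)nc(C)c2C)cc1` gives 39%. Among the measured compounds shown here, the only single-point step among them runs opposite to the change considered here: a number 24.2 percentage points higher from compound 2 to compound 3 (beyond the scatter). Compound 4 `COc1cc(OC)cc(-n2c(-c3ccc(F)cc3)nc(C)c2C)c1` differs from compound 1 by fluoro in place of hydrogen on an aromatic carbon. Reversing the step seen between compound 2 and compound 3, a drop beyond the scatter is expected, though compound 1 carries a different substitution pattern on its other ring, so the size is uncertain. Compound 4 is therefore expected to give 30%, between 15% and 45%, a step of a number 19.5 percentage points lower from compound 1 to compound 4 (beyond the scatter).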

Compound 4, a percentage reported as activity, at one concentration (the size of the read-out at that concentration, not a potency): 55.2%
Beside the measured number, compound 4's estimate is 25.2 percentage points below it; measured number above the stated range.
By their numbers in this assay, from the lowest: compound 2; then compounds 1, 4 and 3 (each within the scatter of the next, the first and the last beyond it).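

On the core of compound 1, phenyl to 4-fluorophenyl gives a number 5.7 percentage points higher from compound 1 to compound 4 (within the scatter) in this assay, so the clear loss linked to fluoro on the other core does not recur here. The outcome of this change at this position therefore depends on the core that carries it: the same change on two cores in this assay, a number 24.2 percentage points higher (beyond the scatter) from compound 2 to compound 3 and a number 5.7 percentage points lower (within the scatter) from compound 4 to compound 1, 29.9 percentage points apart, beyond the scatter of two such steps

The compounds shown leave open which difference between the two cores separates these steps. They also leave open how chloro, a nitrile or an amine in the same place, on an aromatic carbon para to a large group, would read on either core.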